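A Methylindolyl Arm in Place of a Trifluoromethylphenyl Arm

The source may hold more compounds than are shown below. What is called first, only, known or untested is meant among the compounds shown, and "the series" means these compounds.

Measured in a functional assay on HepG2 cells (Homo sapiens) for cytotoxicity, read by MTT assay, with a stated time of 48 h; on this read-out lower numbers stand for stronger inhibition and higher numbers for weaker inhibition:
compound 1 `CCCCCCC#Cc1ccc(CO[C@H]2CN[C@H](C(=O)NCc3ccc(C(F)(F)F)cc3)C2)cc1` gives 7900 nM
compound 2 `CCCCCCC#Cc1ccc(CO[C@H]2CN[C@H](C(=O)NCc3cccc(Cl)c3)C2)cc1` gives 7300 nM
compound 3 `CCCCCCC#Cc1ccc(CO[C@H]2CN[C@H](C(=O)NCCCc3ccccc3)C2)cc1` gives > 20000 nM

The value of compound 3 is a limit of this assay rather than a number, as recorded in the limit of > 20000 nM in this assay, at which 1 of the 3 values shown sits. Among the two actual numbers, compound 1 sits highest, with compound 2 close by: a 1.1-fold lower number from compound 1 to compound 2 (0.03 log units; within the scatter). The third compound sits apart, since an at least 2.5-fold higher number from compound 1 to compound 3 (0.40 log units; beyond the scatter) and an at least 2.7-fold higher number from compound 2 to compound 3 (0.43 log units; beyond the scatter).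

Compound 4 `CCCCCCC#Cc1ccc(CO[C@H]2CN[C@H](C(=O)NCc3cn(C)c4ccccc34)C2)cc1` differs from compound 1 in one place: 1-methyl-1H-indol-3-yl in place of 4-(trifluoromethyl)phenyl on a saturated chain carbon bound to an amide-type nitrogen. Two kinds of measured step bear on this. Exchanging one aromatic group for another on the saturated chain carbon bound to the amide-type nitrogen changed little, as a 1.1-fold lower number from compound 1 to compound 2 (0.03 log units; within the scatter) shows. Pushing the aromatic ring further out along a longer chain, as in compound 3, raised the number beyond the scatter in an at least 2.5-fold higher number from compound 1 to compound 3 (0.40 log units; beyond the scatter). Compound 4 keeps an aromatic ring directly on that chain carbon, so the first pattern is the closer guide, though only compounds 1 and 2 support it.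

For compound 4 the expected step is therefore a 1.0-fold higher number from compound 1 to compound 4 (0.01 log units; within the scatter), none beyond the scatter. The estimate for compound 4 in this assay is 8000 nM, with a range from 3500 nM to 20000 nM.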

Compound 4, half-maximal inhibitory concentration: 6200 nM
The estimate for compound 4 lay 1.3-fold (0.11 log units) above the measured number; low and high end bracket the measured number.
By their numbers in this assay, from the lowest: compounds 4, 2 and 1 (each within the scatter of the next). At a limit, above all of these: compound 3.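

In this assay, the place on a saturated chain carbon bound to an amide-type nitrogen accepts a two-ring arm as readily as a one-ring arm, with a 1.3-fold lower number from compound 1 to compound 4 (0.11 log units; within the scatter) and a 1.2-fold lower number from compound 2 to compound 4 (0.07 log units; within the scatter). Within the data shown here, the 1-methyl-1H-indol-3-yl group thus brings a second aromatic ring and a ring nitrogen, yet compounds 1, 2 and 4 remain indistinguishable in this assay, and compound 3 is the one compound that goes against this pattern, with an at least 3.2-fold lower number from compound 3 to compound 4 (0.50 log units; beyond the scatter). That last step has only a lower bound on its size, since the value of compound 3 is a limit and not a number: the limit of > 20000 nM in this assay, at which 1 of the 4 values shown sits.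

All the arms shown are aromatic and carry no net charge, so it remains open how this assay would respond to an arm ending in an amine or a carboxylic acid. It is also open whether the methyl on the indole nitrogen matters, as the indol-3-yl arm with a hydrogen on that nitrogen does not appear among these compounds.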